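Amide-nitrogen substituent: from compound 2 to compound 4

This account rests on a few compounds, and the source may have more. Where it says the series, first, only, none or still open, it means among the compounds named here.

In a functional assay on Shh Light II cells (Mus musculus) for inhibition, read by a luciferase reporter (a higher number here means a weaker inhibitor, a lower number a stronger inhibitor), compound 2 `O=C(NCC1CCC1)N1CCC(c2nc(-c3ccc4ccccc4n3)no2)CC1` gives 410 nM. Compound 3 `Cn1c(-c2noc(C3CCN(C(=O)NC4CCS(=O)(=O)CC4)CC3)n2)nc2ccccc21`, which carries a different core, gives 350 nM, within the scatter of compound 2. Compound 1 `O=C(NC1CCNCC1)N1CCC(c2nc(-c3ccc4ccccc4n3)no2)CC1` gives 2500 nM, a clearly higher number and beyond the scatter of the other two.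

The next change leads to compound 4 `O=C(Nc1ccccc1C(F)(F)F)N1CCC(c2nc(-c3ccc4ccccc4n3)no2)CC1`, with 2-(trifluoromethyl)phenyl in place of cyclobutylmethyl on an amide-type nitrogen. Within the data shown here, only one measured step bears on this place: a 6.1-fold lower number from compound 1 to compound 2 (0.79 log units; beyond the scatter), a modest step beyond the scatter. It involves a different leaving group, and no aromatic group on this nitrogen has been measured, so it is a thin guide. Resting on that single step, a smaller move in the same direction, towards a lower number, is expected, and no change at all cannot be excluded. The expected step is a 2.7-fold lower number from compound 2 to compound 4 (0.44 log units; beyond the scatter). For compound 4 the estimate is 150 nM, with an expected range of 30 nM to 700 nM.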

Compound 4, half-maximal inhibitory concentration: 700 nM
Estimate against measurement, compound 4: 4.7-fold (0.67 log units) below; the range from low to high includes it.
By their numbers in this assay, from the lowest: compounds 3, 2 and 4 (each within the scatter of the next); then compound 1.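

In this assay the amide-type nitrogen accepts an aromatic ring as well as a non-aromatic one: with 2-(trifluoromethyl)phenyl in place of cyclobutylmethyl there is a 1.7-fold higher number from compound 2 to compound 4 (0.23 log units; within the scatter) and so no separation between the two groups. Against piperidin-4-yl the aromatic group gives a 3.6-fold lower number from compound 1 to compound 4 (0.55 log units; beyond the scatter) and thus a modest step, so on the shared core piperidin-4-yl stays apart from both other substituents. No measured evidence bears on why these groups compare as they do.

Plain phenyl on this nitrogen would separate the contribution of the trifluoromethyl group from that of the ring itself. Cyclohexyl in place of piperidin-4-yl would show whether the ring nitrogen of piperidin-4-yl goes with the higher number of compound 1 2500 nM on this core.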